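Replacing one fluoro in compound 1

The source may hold more compounds than are shown below. What is called first, only, known or untested is meant among the compounds shown, and "the series" means these compounds.

Measured in a functional assay on the whole organism (trachea) for inhibition, with Cavia porcellus as the target; a higher number here means that more compound is needed for the effect, a lower number that less compound is needed:
Compound 1 `CN(Cc1cc(C(F)(F)F)cc(C(F)(F)F)c1)C(=O)c1c(-c2ccc(F)cc2)c2cccnc2c(=O)n1C`: 0.017 mg/kg
Compound 2 `Cn1c(C(=O)NCc2cc(C(F)(F)F)cc(C(F)(F)F)c2)c(-c2ccc(F)cc2)c2cccnc2c1=O`: 0.48 mg/kg

Compound 1, at 0.017 mg/kg, holds the lower of the two numbers in this assay. Compound 3 `CN(Cc1cc(C(F)(F)F)cc(C(F)(F)F)c1)C(=O)c1c(-c2ccccc2)c2cccnc2c(=O)n1C` has not yet been measured. It differs from compound 1 by hydrogen in place of fluoro on an aromatic carbon. For the measured compounds named here, the only measured step, a 28-fold higher number from compound 1 to compound 2 (1.45 log units; beyond the scatter), is large, but it records a different change, hydrogen in place of methyl on an amide-type nitrogen. Going by the values given here, it shows that a single small change can move the number a long way, yet no measured step tests the fluoro itself. Among the compounds with values here, a small step is therefore expected, leaning towards a higher number only since compound 1 is the lower of the two so far. The estimated change is a 1.8-fold higher number from compound 1 to compound 3 (0.25 log units; within the scatter). For compound 3 the expected value is 0.03 mg/kg, with an estimated range of 0.01 mg/kg to 0.1 mg/kg.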

Compound 3, dose for half-maximal effect: 0.027 mg/kg
Beside the measured number, compound 3's estimate is 1.1-fold (0.05 log units) above it; the measured number falls inside the stated range.
By their numbers in this assay, from the lowest: compounds 1 and 3 (each within the scatter of the next); then compound 2.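

In this assay, going from 4-fluorophenyl to phenyl gives a 1.6-fold higher number from compound 1 to compound 3 (0.20 log units; within the scatter) and so provides the first measured test of the fluoro, which the earlier step at the amide nitrogen could not give. At this position on the aromatic ring, para to a large group, hydrogen in place of fluoro leaves the number within the scatter, so the fluoro is not needed to keep it low in this assay. No supporting measurement is available to explain this result.

The compounds shown leave open whether a chloro or methoxy group at this same position would also stay within the scatter of compound 1. They also leave open whether an ethyl group on the amide nitrogen would keep the number close to that of compound 1.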